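A few compounds are considered here, and "the series" means these few. Any claim that something is new, unique, unknown or untested is made for them only; others in the source may bear on it.

Of the compounds shown here, three built on one shared core have been measured in a functional assay on OVCAR-3 cells (Homo sapiens) for inhibition, read by MTT assay, with a stated time of 24 h; a lower number here means a stronger inhibitor, a higher number a weaker inhibitor. Compound 1 `CC1(C)[C@H]2CC[C@]1(C)N(Cc1cn(-c3ccc(C#N)cc3)nn1)C(=O)C2` gives 380 nM. Compound 2 `CC1(C)[C@H]2CC[C@]1(C)N(Cc1cn(-c3ccccc3Cl)nn1)C(=O)C2` gives 40 nM, and compound 3 `CC1(C)[C@H]2CC[C@]1(C)N(Cc1cn(-c3ccccc3)nn1)C(=O)C2` gives 50 nM. Compound 2 stands apart from compound 1 by the step of a 9.5-fold lower number from compound 1 to compound 2 (0.98 log units; beyond the scatter), which lies beyond the scatter, while its step to compound 3, a 1.3-fold higher number from compound 2 to compound 3 (0.10 log units; within the scatter), lies within the scatter, so compounds 2 and 3 cannot be separated on these figures. The step of a 7.6-fold lower number from compound 1 to compound 3 (0.88 log units; beyond the scatter) is likewise beyond the scatter.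

Compound 4 `Cc1ccccc1-n1cc(CN2C(=O)C[C@@H]3CC[C@@]2(C)C3(C)C)nn1` has not yet been measured. It differs from compound 2 in one place: methyl in place of chloro on an aromatic carbon. Going by the values given here, the measured step that bears on this is a 1.3-fold higher number from compound 2 to compound 3 (0.10 log units; within the scatter), in which the chloro was removed altogether and the number hardly moved; no measured step exchanges chloro for methyl. The expectation is therefore that the step of a 1.1-fold higher number from compound 2 to compound 4 (0.05 log units; within the scatter) stays within the scatter. For compound 4 the estimate in this assay is 45 nM, with a range from 20 nM to 110 nM.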

Compound 4, half-maximal inhibitory concentration: 150 nM
Estimate against measurement, compound 4: 3.3-fold (0.52 log units) below; measured number outside the range, above it.
By their numbers in this assay, from the lowest: compounds 2 and 3 (each within the scatter of the next); then compound 4; then compound 1.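

In this assay, the aromatic carbon ortho to a large group is not indifferent to what it carries: chloro and hydrogen there could not be told apart, yet methyl gives a 3.8-fold higher number from compound 2 to compound 4 (0.57 log units; beyond the scatter) and a 3.0-fold higher number from compound 3 to compound 4 (0.48 log units; beyond the scatter). Chloro and methyl each bring one heavy atom and neither adds a hydrogen-bond donor or acceptor, so these counts do not capture the difference between them at this position. The 2-methylphenyl group still compares well with 4-cyanophenyl, with a 2.5-fold lower number from compound 1 to compound 4 (0.40 log units; beyond the scatter), which places compound 4 between the other compounds rather than at the weak end.

Nothing available here accounts for the difference between methyl and chloro at this carbon. From the compounds shown here alone, it remains open whether fluoro, methoxy or a longer chain such as ethyl at the same place would read like chloro and hydrogen or like methyl.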